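Swapping the aryl carbonyl on a shortened chain

The source may hold more compounds than are shown below. What is called first, only, known or untested is meant among the compounds shown, and "the series" means these compounds.

Of the compounds shown here, three of one series have been measured in an assay on isolated protein for inhibition of serine protease 1 (Homo sapiens); on this read-out higher numbers stand for weaker inhibition and lower numbers for stronger inhibition. Compound 1 `N=C(N)N1CCC[C@H](NC(=O)CNC(=O)[C@@H](CCCNC(=O)c2cnccn2)NS(=O)(=O)Cc2ccccc2)C1O` gives 324 nM. Compound 2 `N=C(N)NCCCC(NS(=O)(=O)Cc1ccccc1)C(=O)NCC(=O)N[C@H]1CCCN(C(=N)N)C1O` gives 75 nM. Compound 3 `N=C(N)N1CCC[C@H](NC(=O)CNC(=O)[C@@H](CCNC(=O)c2ccc(O)nc2)NS(=O)(=O)Cc2ccccc2)C1O` gives 26.6 nM, the lowest of the three numbers, with compound 2 nearest and compound 1 furthest.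

Compound 4 `N=C(N)N1CCC[C@H](NC(=O)CNC(=O)[C@@H](CCNC(=O)c2cnccn2)NS(=O)(=O)Cc2ccccc2)C1O` is still unmeasured. It differs from compound 3 in one place: pyrazin-2-yl in place of 6-hydroxypyridin-3-yl on a carbonyl carbon. Within the data shown here, the only measured step that touches this ring is a 12-fold lower number from compound 1 to compound 3 (1.09 log units; beyond the scatter), but that step also shortened the chain by one carbon, so the share of the ring swap alone cannot be separated. Compound 4 keeps the shorter chain of compound 3 while taking back the ring of compound 1, so it is expected to sit between those two, closer to compound 3; the expected step is a 3.8-fold higher number from compound 3 to compound 4 (0.58 log units; beyond the scatter), a rise in this assay. For compound 4 the estimate is 100 nM, with a range from 35 nM to 300 nM.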

Compound 4, half-maximal inhibitory concentration: 166 nM
Compound 4: the middle estimate sits 1.7-fold (0.22 log units) below what was measured, and the stated range covers the measured number.
By their numbers in this assay, from the lowest: compound 3; then compound 2; then compounds 4 and 1 (each within the scatter of the next).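

In this assay the step of a 6.2-fold higher number from compound 3 to compound 4 (0.80 log units; beyond the scatter) isolates the ring swap on the shorter chain and shows that, on this carbonyl carbon, 6-hydroxypyridin-3-yl gives clearly stronger inhibition than pyrazin-2-yl. With pyrazin-2-yl held fixed, the chain change alone gives a 2.0-fold lower number from compound 1 to compound 4 (0.29 log units; within the scatter) and so stays within the scatter, which places much of the earlier step of a 12-fold lower number from compound 1 to compound 3 (1.09 log units; beyond the scatter) with the ring rather than with the chain length. Nothing available here explains why the ring swap has this effect.

Going by these compounds, it remains open whether 6-hydroxypyridin-3-yl would give the same gain on the longer chain of compound 1. On these data alone, it is also open whether an amine or a carboxylic acid in place of the hydroxy group would keep the lower number seen for compound 3.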